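Adding an Amino Group to the Better Stereoisomer

The source may hold more compounds than are shown below. What is called first, only, known or untested is meant among the compounds shown, and "the series" means these compounds.

In a functional assay on MCF7 cells (Homo sapiens) for antiproliferative activity, read by MTT assay, with stated times of 24 h and 72 h (a lower number here means a stronger inhibitor, a higher number a weaker inhibitor), compound 1 `COc1ccc([C@@H]2[C@H](Oc3ccccc3)C(=O)N2c2cc(OC)c(OC)c(OC)c2)cc1` gives 35000 nM, while compound 2 `COc1ccc([C@@H]2[C@@H](Oc3ccccc3)C(=O)N2c2cc(OC)c(OC)c(OC)c2)cc1` gives 6900 nM, the lower of the two numbers. This step, a 5.1-fold lower number from compound 1 to compound 2 (0.71 log units; beyond the scatter), comes with the fact that compounds 1 and 2 differ only in the configuration as drawn, so it says little about ring substituents. Compound 3 `COc1ccc([C@@H]2[C@@H](Oc3ccccc3)C(=O)N2c2cc(OC)c(OC)c(OC)c2)cc1N` differs from compound 2 by amino in place of hydrogen on an aromatic carbon, turning 4-methoxyphenyl into 3-amino-4-methoxyphenyl. Going by the values given here, no measured step covers such a change, so the expectation is a tentative one, and its range is wide. A clearly lower number is expected, an estimated 23-fold lower number from compound 2 to compound 3 (1.36 log units; beyond the scatter). For compound 3 the expected value is 300 nM, with an estimated range of 20 nM to 4000 nM.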

Compound 3, half-maximal inhibitory concentration: 13 nM
Compound 3: the middle estimate sits 23-fold (1.36 log units) above what was measured; measured number outside the range, below it.
By their numbers in this assay, from the lowest: compound 3; then compound 2; then compound 1.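

In this assay, an amino group on the aromatic carbon ortho to a methoxy group produces a 530-fold lower number from compound 2 to compound 3 (2.72 log units; beyond the scatter), a much larger step than the one from configuration alone, a 5.1-fold lower number from compound 1 to compound 2 (0.71 log units; beyond the scatter). This aromatic position, in the change from 4-methoxyphenyl to 3-amino-4-methoxyphenyl, therefore moves the number far more through a single heavy atom than the stereocentre does. Nothing given here bears on why this step is so large.

On these data alone, whether the amino group itself is needed stays open, since a hydroxyl or a methylamino group on the same carbon would test that. Also open, as far as these compounds go, is whether the amino group would have a similar effect in the configuration of compound 1.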